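The compounds below may be only part of what the source reports. "The series", "measured", "known", "first", "only" and "open" are said of these compounds alone.

Compound 1 `COc1ccc(CNc2nc([Se]C)nc3ccccc23)cc1` stands only at a limit in a functional assay on HTB-54 cells (Homo sapiens) for cytotoxicity, read by MTT assay, with a stated time of 72 h; on this read-out lower numbers stand for stronger inhibition of growth and higher numbers for weaker inhibition of growth. In this assay compound 1 gives > 100000 nM, a limit rather than a number. Compound 3 `C[Se]c1nc(NCc2ccccc2)c2ccccc2n1` likewise gives a limit in this assay, > 100000 nM. The step that the two limits leave unreadable from compound 1 to compound 3 is thus unreadable, and the limit of > 100000 nM in this assay, at which 2 of the 3 values shown sit, shows where both values sit. Compound 2 `C[Se]c1nc([Se]C)c2cccnc2n1` gives "not determined" (no result reported) in this assay. Compound 4 `COc1ccc(CNc2nc(SC)nc3ccccc23)cc1` differs from compound 1 in a group of 2 heavy atoms (1 carbon, 1 sulfur; no ring) in place of a group of 2 heavy atoms (1 carbon, 1 selenium; no ring), on an aromatic carbon. Within the data shown here, no measured step follows this exchange, so neither its size nor its direction is readable from the data. Compound 4 is expected to sit at 150000 nM in this assay, between 30000 nM and 1000000 nM, the step that the limit leaves unreadable from compound 1 to compound 4 expected to stay within the scatter because of the limit of > 100000 nM in this assay, at which 2 of the 3 values shown sit.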

Compound 4, concentration for total growth inhibition: > 100000 nM
Compound 4: no number, only a limit; the forecaster's own chance of this, stated with the estimate: 80%; the middle value lies beyond the limit too.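

Among these compounds, compound 4 gives > 100000 nM in this assay, a limit and not a number, so no step from compound 1 to compound 4 can be read: the limit of > 100000 nM in this assay, at which 3 of the 4 values shown sit. The compounds shown leave open how strongly any of them inhibits growth, and whether the methylsulfanyl group and its selenium counterpart differ at all.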